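Swapping a Ring Ether for a Ring Amine

A few compounds are considered here, and "the series" means these few. Any claim that something is new, unique, unknown or untested is made for them only; others in the source may bear on it.

In a functional assay on MV4-11 cells (Homo sapiens) for antiproliferative activity, read by CellTiter-Glo, with a stated time of 72 h (on this read-out higher numbers stand for weaker inhibition of growth and lower numbers for stronger inhibition of growth), three compounds share one core. Compound 1 `Clc1cnc(Nc2ccccc2)cc1-c1csc(NCC2CCOCC2)n1` reaches only the limit > 10000 nM. For the measured compounds named here, compound 2 `N[C@H]1CC[C@H](CNc2cc(-c3csc(NCC4CCOCC4)n3)c(Cl)cn2)CC1` gives 1900 nM, and the single change between them, (4-aminocyclohexyl)methyl in place of phenyl on a nitrogen on an aromatic ring, yields an at least 5.2-fold lower number from compound 1 to compound 2 (0.72 log units; beyond the scatter). Compound 3 `COCCN[C@H]1CC[C@H](Nc2cc(-c3csc(OCC4CCOCC4)n3)c(Cl)cn2)CC1` gives 570 nM, the lowest of the two numbers, with compound 2 a clear step above it. Compound 4 `COCCN[C@H]1CC[C@H](Nc2cc(-c3csc(NCC4CCOC4)n3)c(Cl)cn2)CC1` differs from compound 3 only through (((oxolan-3-yl)methyl)amino in place of (oxan-4-yl)methoxy on an aromatic carbon). Going by the values given here, no measured step touches this position; the only measured step concerns a different part of the core, so it offers little guidance. The change is expected to be small, a 1.0-fold lower number from compound 3 to compound 4 (0.02 log units; within the scatter), within the scatter. Compound 4 is estimated at 550 nM, expected between 170 nM and 1800 nM.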

Compound 4, concentration for 50% growth inhibition: 493 nM
Compound 4: middle estimate off by 1.1-fold (0.05 log units), on the high side; measured number inside the range.
By their numbers in this assay, from the lowest: compounds 4 and 3 (each within the scatter of the next); then compound 2. At a limit, above all of these: compound 1.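

In this assay, putting ((oxolan-3-yl)methyl)amino in place of (oxan-4-yl)methoxy gives a 1.2-fold lower number from compound 3 to compound 4 (0.06 log units; within the scatter). This position on the five-membered aromatic ring therefore accepts a smaller ring, a nitrogen link instead of an oxygen link and a hydrogen-bond donor, with no readable shift in growth inhibition. Nothing measured here explains this outcome. Going by these compounds, since ring and link changed together, their separate contributions remain unknown. Also open, on these data alone, is how a carboxylic acid or an open carbon chain without a ring would fare at this position.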